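The compounds below may be only part of what the source reports. "The series", "measured", "known", "first", "only" and "open" are said of these compounds alone.

Working notes on the series. Compound 3 `Cc1ccc(COc2ccc(C(=O)NC(=O)Nc3ccc(C)c(-c4nc5ccccc5[nH]4)c3)cc2)cc1` gives the lowest number of the three measured in a functional assay on MGC-803 cells (Homo sapiens) for inhibition, read by MTT assay, with a stated time of 48 h (a lower number here means a stronger inhibitor, a higher number a weaker inhibitor), at 4250 nM; compound 2 `Cc1ccc(NC(=O)NC(=O)c2ccc(OCc3cccc(C(F)(F)F)c3)cc2)cc1-c1nc2ccccc2[nH]1` gives 13100 nM and compound 1 `Cc1ccc(NC(=O)NC(=O)c2ccc(OCc3ccc(C(F)(F)F)cc3)cc2)cc1-c1nc2ccccc2[nH]1` gives 14900 nM. Compound 4 `Cc1ccc(NC(=O)NC(=O)c2ccc(OCc3ccccc3Cl)cc2)cc1-c1nc2ccccc2[nH]1` differs from compound 3 by 2-chlorophenyl in place of 4-methylphenyl on a saturated chain carbon bound to an oxygen on an aromatic ring. Among the measured compounds shown here, two measured steps bear on this position: the step of a 1.1-fold lower number from compound 1 to compound 2 (0.06 log units; within the scatter), a change of the same kind within the scatter, and the step of a 3.1-fold lower number from compound 2 to compound 3 (0.49 log units; beyond the scatter), a modest shift. The entering group is a halogenated ring like those of compound 1 and compound 2, so compound 4 is expected to give a somewhat higher number than compound 3, with a 1.8-fold higher number from compound 3 to compound 4 (0.25 log units; within the scatter). The estimate for compound 4 in this assay is 7500 nM, in the range 3000 nM to 19000 nM.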

Compound 4, half-maximal inhibitory concentration: 19500 nM
Compound 4: middle estimate off by 2.6-fold (0.41 log units), on the low side; measured number outside the range, above it.
By their numbers in this assay, from the lowest: compound 3; then compounds 2, 1 and 4 (each within the scatter of the next).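

In this assay, 2-chlorophenyl in place of 4-methylphenyl gives a 4.6-fold higher number from compound 3 to compound 4 (0.66 log units; beyond the scatter), a modest step beyond the scatter. The chlorine-bearing ring does not separate from the two trifluoromethyl-bearing rings, with a 1.5-fold higher number from compound 2 to compound 4 (0.17 log units; within the scatter) and a 1.3-fold higher number from compound 1 to compound 4 (0.12 log units; within the scatter) both within the scatter, so among these four compounds only the 4-methylphenyl group of compound 3 stands apart. No measurement shown here offers an explanation for this result.

Going by these compounds, whether the step follows from the change of group or from its position on the ring remains open. A 4-chlorophenyl or 2-methylphenyl group at this position would separate the two.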